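The compounds below may be only part of what the source reports. "The series", "measured", "known", "first", "only" and "open" are said of these compounds alone.

Compound 1 `N#CCCCc1c[nH]c2ccc(C(=O)O)cc12` is recorded in an assay on isolated protein (urine) for inhibition of Myeloperoxidase (Homo sapiens), with a stated time of 5 min (a higher number here means a weaker inhibitor, a lower number a stronger inhibitor), as "not active" (no number reported). Compound 2 `CCSCCc1c[nH]c2ccc(F)cc12` gives in this assay only a limit of the assay, > 100 nM, so no single number places it; (the limit of > 100 nM in this assay, at which 1 of the 2 values shown sits). Compound 3 `ONCCCc1c[nH]c2ccc(F)cc12` has not yet been measured. It differs from compound 2 in one place: (hydroxyamino)methyl in place of ethylsulfanyl on a saturated chain carbon, two bonds along the chain from an aromatic carbon. Among the measured compounds shown here, no measured step stands between these compounds, so the size of the change is open. A step toward stronger inhibition is expected, with the move from compound 2 to compound 3 in this assay estimated at an at least 2.5-fold lower number from compound 2 to compound 3 (0.39 log units; beyond the scatter). Compound 3 is therefore expected in this assay near 40 nM, within a range from 8 nM to 300 nM.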

Compound 3, half-maximal inhibitory concentration: 11 nM
For compound 3 the middle estimate is 3.6-fold (0.56 log units) above the measured one; the range from low to high includes it.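

In this assay, the change from ethylsulfanyl to (hydroxyamino)methyl on a saturated chain carbon, two bonds along the chain from an aromatic carbon, gives an at least 9.0-fold lower number from compound 2 to compound 3 (0.95 log units; beyond the scatter). This shows that the group carried at this chain position can strongly affect inhibition, and compound 3 is the only compound shown with a single number. Compound 2 stands only at a limit, so this step is a minimum: the limit of > 100 nM in this assay, at which 1 of the 3 values shown sits.

As far as these compounds go, how an amine or a longer chain would compare at this position remains open. Compound 1 differs from compound 3 in more than one place, so it does not show what the fluorine contributes.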